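Chain lengthening on the imidazole and MDCK cytotoxicity

The compounds below may be only part of what the source reports. "The series", "measured", "known", "first", "only" and "open" are said of these compounds alone.

Measured compounds:
compound 1 `CCc1ncc(CN[C@@H]2C[C@@H]3C[C@H]([C@H]2C)C3(C)C)[nH]1` 137000 nM
compound 2 `CCCCc1ncc(CN[C@@H]2C[C@@H]3C[C@H]([C@H]2C)C3(C)C)[nH]1` 70400 nM
compound 3 `Cc1nc(C(C)C)[nH]c1CN[C@@H]1C[C@@H]2C[C@H]([C@H]1C)C2(C)C` 73100 nM

All three were tested in an ADME assay on MDCK cells (Canis lupus familiaris) for cytotoxicity, read by MTT assay, with a stated time of 48 h; on this read-out lower numbers stand for higher toxicity in this test and higher numbers for lower toxicity in this test. Compound 2 carries ethyl in place of hydrogen on a saturated chain carbon, two bonds along the chain from an aromatic carbon relative to compound 1, and the step was a 1.9-fold lower number from compound 1 to compound 2 (0.29 log units; within the scatter). The difference between the core of compound 1 and the core of compound 3 is not broken down here. Compound 4 `CCCc1nc(C(C)C)[nH]c1CN[C@@H]1C[C@@H]2C[C@H]([C@H]1C)C2(C)C` has not yet been measured; it carries ethyl in place of hydrogen on a saturated chain carbon bound to an aromatic carbon relative to compound 3. The two changes are the same kind of change, though not the same: in compound 2 the chain carbon sits two bonds along the chain from an aromatic carbon, in compound 4 it is bound to an aromatic carbon. Because a 1.9-fold lower number from compound 1 to compound 2 (0.29 log units; within the scatter) was within the scatter, the step of a 1.6-fold lower number from compound 3 to compound 4 (0.21 log units; within the scatter) is expected to be modest. Compound 4 is estimated at 45000 nM, between 20000 nM and 95000 nM.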

Compound 4, half-maximal cytotoxic concentration: 156000 nM
Beside the measured number, compound 4's estimate is 3.5-fold (0.54 log units) below it; measured number outside the range, above it.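

In this assay, ethyl in place of hydrogen on a saturated chain carbon bound to an aromatic carbon gave a 2.1-fold higher number from compound 3 to compound 4 (0.33 log units; beyond the scatter). Set beside the earlier step, the same kind of change did not carry over unchanged from one core to the other: the same change on two cores in this assay, a 1.9-fold lower number (0.29 log units; within the scatter) from compound 1 to compound 2 and a 2.1-fold higher number (0.33 log units; beyond the scatter) from compound 3 to compound 4, 4.2-fold (0.62 log units) apart, beyond the scatter of two such steps. This shows that the step on the core of compound 1 was a poor guide to the step on the core of compound 3, but it does not show why, as there is one pair per core and the chain carbon sits two bonds along the chain from an aromatic carbon in one pair and is bound to an aromatic carbon in the other.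

The compounds shown leave open how a longer chain, such as hexyl, would behave on either core. They also leave open what a terminal amine or a carboxylic acid on the chain would do in this assay.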